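The compounds below may be only part of what the source reports. "The series", "measured", "known", "first", "only" and "open" are said of these compounds alone.

Compound 1 `Cc1cc(Nc2nc3nonc3nc2O)ccc1OCC(F)(F)F` gives 7000 nM; compound 2 `Oc1nc2nonc2nc1Nc1ccc(OCC(F)(F)F)c(F)c1` gives 10400 nM; compound 3 `Oc1nc2nonc2nc1Nc1ccc(OCC(F)(F)F)c(C(F)(F)F)c1` gives 4000 nM. All three share one core and differ only in the group on an aromatic carbon. In an assay on mitochondria from L6 cells (Rattus norvegicus) for activation, with a stated time of 90 min (a higher number here means that more compound is needed for the effect, a lower number that less compound is needed), compound 2 has the highest of the three numbers, though compound 1 sits within the scatter of it (a 1.5-fold higher number from compound 1 to compound 2 (0.17 log units; within the scatter)), while compound 3 lies beyond it (a 2.6-fold lower number from compound 2 to compound 3 (0.41 log units; beyond the scatter)). Compound 4 `Oc1nc2nonc2nc1Nc1ccc(OC(F)(F)F)c(F)c1` is not yet measured; it differs from compound 2 by trifluoromethyl in place of 2,2,2-trifluoroethyl on an oxygen on an aromatic ring. For the measured compounds named here, none of the measured steps touches this oxygen-borne group, so nothing measured here says which way, if any, the number should move. The step from compound 2 to compound 4 is therefore expected to be a 1.0-fold lower number from compound 2 to compound 4 (0.02 log units; within the scatter). For compound 4 the estimate is 10000 nM, with a range from 4000 nM to 25000 nM.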

Compound 4, half-maximal effective concentration: 2900 nM
Beside the measured number, compound 4's estimate is 3.4-fold (0.54 log units) above it; the whole stated range lies above it.
By their numbers in this assay, from the lowest: compounds 4, 3, 1 and 2 (each within the scatter of the next, the first and the last beyond it).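

Until now only the group on the aromatic carbon had changed. In this assay, changing 2,2,2-trifluoroethoxy to trifluoromethoxy gives a 3.6-fold lower number from compound 2 to compound 4 (0.55 log units; beyond the scatter) and so shows that the number also responds to the group on the oxygen on the aromatic ring. Nothing available explains this shift.

From the compounds shown here alone, whether the same change would act alike alongside the methyl of compound 1 or the trifluoromethyl of compound 3 remains open. So does how a plain methoxy or a longer chain, such as propoxy, would read in this place.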